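Isopropyl in place of methyl on the amino nitrogen

A few compounds are considered here, and "the series" means these few. Any claim that something is new, unique, unknown or untested is made for them only; others in the source may bear on it.

Compound 1, `Nc1nc2ccccn2c1-c1ccc(O)cc1`: in an assay on isolated protein for inhibition of ubiquitin carboxyl-terminal hydrolase 1 (Homo sapiens) (on this read-out higher numbers stand for weaker inhibition and lower numbers for stronger inhibition), compound 1 gives > 100000 nM, which is a limit of the assay.
Compound 2, `CN(C)c1nc2ccccn2c1-c1ccc(O)cc1`: in this assay compound 2 gives > 100000 nM, again a limit.
Compound 3, `CNc1nc2ccccn2c1-c1ccc(O)cc1`: in this assay compound 3 gives > 100000 nM, also a limit.

Compound 3 therefore stands nowhere in particular on the numbers shown: its value is a limit, and every measured compound sits at the limit of > 100000 nM in this assay, at which 3 of the 3 values shown sit. The unmeasured compound 4 is `CC(C)Nc1nc2ccccn2c1-c1ccc(O)cc1`, reached from compound 3 by isopropyl in place of methyl on a nitrogen on an aromatic ring.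

Within the data shown here, three measured steps touch the same nitrogen. The step that the two limits leave unreadable from compound 1 to compound 3, the step that the two limits leave unreadable from compound 1 to compound 2 and the step that the two limits leave unreadable from compound 2 to compound 3 are all unreadable, since both ends lie at the limit. None of them tells how far a larger group on this nitrogen moves the value, and nothing else in the set bears on it. The only expectation that can rest on these compounds is that compound 4 stays where compounds 1, 2 and 3 are.

The step from compound 3 to compound 4 is expected to be a number no higher from compound 3 to compound 4 (the limit leaves the size open), that is, no readable change. Compound 4 is accordingly estimated at about 100000 nM, in a range from 30000 nM to 300000 nM, and most likely reported as a limit.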

Compound 4, half-maximal inhibitory concentration: > 100000 nM
Compound 4 was reported as a limit; the forecaster's own chance of this, stated with the estimate: 85%; the middle value sits exactly at the limit.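

In this assay compound 4 gives > 100000 nM, which is a limit. The steps to compound 4 from compound 1, compound 2 and compound 3 therefore cannot be read, and all four compounds sit together: the limit of > 100000 nM in this assay, at which 4 of the 4 values shown sit.

The compounds shown leave open whether any group on this nitrogen changes the inhibition at all.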